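The source may report more compounds than this note shows. Statements on the series, on what has been measured and on what is new or still open speak of the compounds shown alone.

Compound 1 `CCCC1(c2ccccc2)CC(=O)C(C(CC(=O)c2ccc(-c3ccc(Br)cc3)cc2)c2ccccc2)=C(O)O1` in a functional assay on A549 cells (Homo sapiens) for inhibition, with a stated time of 72 h; a higher number here means a weaker inhibitor, a lower number a stronger inhibitor: > 10000 nM, a limit of the assay rather than a number.
Compound 2 `CC1(c2ccccc2)CC(=O)C(C2CC(c3ccc(-c4ccc(Br)cc4)cc3)Cc3ccccc32)=C(O)O1` in this assay: 1830 nM.

Among the measured compounds shown here, of the two compounds measured here, compound 2 is the only one that gives a number in this assay; the other value is the limit of > 10000 nM in this assay, at which 1 of the 2 values shown sits, so compound 2 cannot be ranked against it beyond noting that it, and not compound 1, returned a measurable half-maximal inhibitory concentration.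

Compound 3 `COc1ccc(C2Cc3ccccc3C(C3=C(O)OC(C)(c4ccccc4)CC3=O)C2)cc1` has not yet been measured in this assay. It differs from compound 2 in one place: methoxy in place of 4-bromophenyl on an aromatic carbon. For the measured compounds named here, because no step between two measured compounds is available, the size of this change can only be guessed. The expectation is that the step from compound 2 to compound 3 is a 3.3-fold higher number from compound 2 to compound 3 (0.52 log units; beyond the scatter), in the direction of a weaker inhibitor, beyond the usual scatter. On that basis compound 3 is estimated to give 6000 nM in this assay, with a likely range from 1800 nM to 20000 nM, and with a real chance that, like compound 1, it returns only a limit.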

Compound 3, half-maximal inhibitory concentration: > 10000 nM
Compound 3: no number, only a limit; the forecaster's own chance of this, stated with the estimate: 35%; middle value at least 1.6-fold (0.22 log units) from the limit.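

Among the compounds shown here, replacing 4-bromophenyl with methoxy on this aromatic carbon gives the first step that can be read in this assay: an at least 5.4-fold higher number from compound 2 to compound 3 (0.73 log units; beyond the scatter), in the direction of a weaker inhibitor. This shows that the place, para to a large group, is not indifferent to what it carries: in this pair, the measurable value of compound 2 is lost when seven heavy atoms, including a six-membered aromatic ring, give way to the two heavy atoms of methoxy. Compound 3 gives > 10000 nM, a limit of the assay and not a number, so the step has a lower bound but no full size, and the result cannot show how much weaker compound 3 really is: the limit of > 10000 nM in this assay, at which 2 of the 3 values shown sit.

The compounds shown leave open which part of the 4-bromophenyl matters, the bromine or the aromatic ring, or whether methoxy itself counts against activity. A plain phenyl, a lone bromine or a 4-methoxyphenyl at this place would separate these readings, and each would need a value that is a number rather than a limit.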